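The compounds below may be only part of what the source reports. "The series", "measured", "known", "first", "only" and "open" are said of these compounds alone.

Compound 2 `CC(C)c1noc(N2CCN(C(=O)[C@@H]3CCCN(S(=O)(=O)c4ccc(S(=O)(=O)C5CCC5)cc4)C3)CC2)n1` gives 70 nM in a functional assay on MIA PaCa-2 cells (Homo sapiens) for inhibition, read by MTT assay, with a stated time of 7 days (a higher number here means a weaker inhibitor, a lower number a stronger inhibitor), the lowest of the two numbers recorded here. Compound 3 `CCOC(=O)[C@@H]1CCN(S(=O)(=O)c2ccc(S(=O)(=O)N(CC)CC)cc2)C1` gives 8600 nM in this assay, a far higher number. Compound 1 `CCOC(=O)N1CCC[C@H](S(=O)(=O)c2ccc(S(=O)(=O)N(CC)CC)cc2)C1` reaches only > 30000 nM in this assay, which is a limit of the measurement rather than a number; (the limit of > 30000 nM in this assay, at which 1 of the 3 values shown sits). Compound 4 `CCN(CC)S(=O)(=O)c1ccc(S(=O)(=O)N2CCC[C@@H](C(=O)N3CCN(c4nc(C(C)C)no4)CC3)C2)cc1` has not yet been measured. It differs from compound 2 in one place: diethylamino in place of cyclobutyl on a sulfonyl sulfur. Compounds 1 and 3 carry this diethylsulfamoyl group but lack the rest of compound 2, so their weak numbers do not isolate the swap. Going by the values given here, no measured pair tests this change alone, so only a small shift is expected, in either direction. Compound 4 is therefore estimated at 110 nM, between 35 nM and 400 nM. The step of a 1.6-fold higher number from compound 2 to compound 4 (0.20 log units; within the scatter) is expected to stay within scatter.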

Compound 4, half-maximal inhibitory concentration: 50 nM
Compound 4: the middle estimate sits 2.2-fold (0.34 log units) above what was measured; the range from low to high includes it.
By their numbers in this assay, from the lowest: compounds 4 and 2 (each within the scatter of the next); then compound 3. At a limit, above all of these: compound 1.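

The swap gives a 1.4-fold lower number from compound 2 to compound 4 (0.15 log units; within the scatter) in this assay, so this pair gives no sign that cyclobutyl and diethylamino differ at this sulfonyl sulfur. In this pair, the four-membered ring is therefore not needed for a low number, and an open-chain diethylamino serves as well. Nothing measured here explains why the two groups match. From the compounds shown here alone, whether dimethylamino, morpholine or a primary amine on this sulfur would keep the number low remains open. So does whether the same swap would give a similar result on a different core.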